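Methyl to pentyl on compound 2

The compounds below may be only part of what the source reports. "The series", "measured", "known", "first", "only" and "open" are said of these compounds alone.

Measured in a functional assay on BGC-823 cells (Homo sapiens) for inhibition, read by MTT assay, with a stated time of 72 h (a lower number here means a stronger inhibitor, a higher number a weaker inhibitor), the compounds read:
compound 1 `Cc1cc(N2CC[C@@H](C)[C@@H](N(C)c3ncnc4[nH]ccc34)C2)n2nc(SCc3ccc(Cl)cc3)nc2n1` gives 26300 nM as a value
compound 2 `Cc1nc2nc(SCc3ccc(Cl)cc3)nn2c(N2CC[C@@H](C)[C@@H](N(C)c3ncnc4[nH]ccc34)C2)c1C` gives > 100000 nM as a limit of the assay
compound 3 `Cc1cc(N2CC[C@@H](C)[C@@H](N(C)c3ncnc4[nH]ccc34)C2)n2nc(SCc3ccc(F)cc3)nc2n1` gives 44300 nM as a value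

Compound 2 stands at the limit of > 100000 nM in this assay, at which 1 of the 3 values shown sits, and so has no number. Compound 4 `CCCCCc1c(C)nc2nc(SCc3ccc(Cl)cc3)nn2c1N1CC[C@@H](C)[C@@H](N(C)c2ncnc3[nH]ccc23)C1` differs from it by butyl in place of hydrogen on a saturated chain carbon bound to an aromatic carbon and the same difference reads methyl to pentyl. The step of an at least 3.8-fold higher number from compound 1 to compound 2 (0.58 log units; beyond the scatter) came with methyl in place of hydrogen on an aromatic carbon, and the step of a 1.7-fold higher number from compound 1 to compound 3 (0.23 log units; within the scatter) came with fluoro in place of chloro on an aromatic carbon. Neither is a change on a saturated chain carbon, so they set no firm size. A modest move toward a lower number is expected, though another limit remains possible. The estimated step in this assay is an at least 2.0-fold lower number from compound 2 to compound 4 (0.30 log units; that floor lies within the scatter) and it stays uncertain. For compound 4 the estimated value is 50000 nM with an expected range from 12000 nM to 150000 nM in all.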

Compound 4, half-maximal inhibitory concentration: 32300 nM
Beside the measured number, compound 4's estimate is 1.5-fold (0.19 log units) above it; the range from low to high includes it.
By their numbers in this assay, from the lowest: compounds 1, 4 and 3 (each within the scatter of the next). At a limit, above all of these: compound 2.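

In this assay, lengthening methyl to pentyl at this position came with an at least 3.0-fold lower number from compound 2 to compound 4 (0.49 log units; beyond the scatter). Against hydrogen on the same aromatic carbon, pentyl came with a 1.2-fold higher number from compound 1 to compound 4 (0.09 log units; within the scatter), so the long chain reads level with hydrogen, whereas the methyl of compound 2 alone had shifted the number upward. The first step is only a floor, because compound 2 stands at a limit of the assay: the limit of > 100000 nM in this assay, at which 1 of the 4 values shown sits.

What the compounds shown leave open is how an ethyl or propyl chain would read here, and whether a chain ending in an amine would read the same.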